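Ethoxy in place of methoxy on a dichloropyridyl urea

A few compounds are considered here, and "the series" means these few. Any claim that something is new, unique, unknown or untested is made for them only; others in the source may bear on it.

Measured so far:
compound 1, `O=C(Nc1ccnc(Cl)c1)Nc1cc(Cl)nc(Cl)c1`, 55300 nM
compound 2, `COc1cc(NC(=O)Nc2cc(Cl)nc(Cl)c2)cc(Cl)n1`, 33200 nM

Compound 1 `O=C(Nc1ccnc(Cl)c1)Nc1cc(Cl)nc(Cl)c1` and compound 2 `COc1cc(NC(=O)Nc2cc(Cl)nc(Cl)c2)cc(Cl)n1` share a urea core and were both tested in an ADME assay on NCM460 cells (Homo sapiens) for cytotoxicity, read by MTT assay, with a stated time of 72 h, in the presence of a further agent that is not named here; a lower number here means that less compound is needed, a higher number that more compound is needed for the effect. In this assay compound 1 gives 55300 nM, and compound 2 gives 33200 nM. Going by the values given here, the single step between them, a 1.7-fold lower number from compound 1 to compound 2 (0.22 log units; within the scatter), leaves the two compounds within the scatter of each other, so compound 2 stands beside compound 1 rather than apart from it.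

Compound 3 `CCOc1cc(NC(=O)Nc2cc(Cl)nc(Cl)c2)cc(Cl)n1` differs from compound 2 by methyl in place of hydrogen on a saturated chain carbon bound to an oxygen on an aromatic ring. Among the compounds with values here, no measured step touches this chain carbon; the only step known, a 1.7-fold lower number from compound 1 to compound 2 (0.22 log units; within the scatter), is the one that brought the methoxy in, and it was within the scatter. On that basis no step beyond the scatter is expected for compound 3 in this assay, and the change is estimated as a 1.1-fold lower number from compound 2 to compound 3 (0.04 log units; within the scatter). Compound 3 is therefore expected to give about 30000 nM, in a range from 12000 nM to 75000 nM.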

Compound 3, half-maximal effective concentration: 25300 nM
The estimate for compound 3 lay 1.2-fold (0.07 log units) above the measured number; the measured number falls inside the stated range.
By their numbers in this assay, from the lowest: compounds 3, 2 and 1 (each within the scatter of the next, the first and the last beyond it).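

In this assay, methyl in place of hydrogen on the saturated chain carbon bound to an oxygen on an aromatic ring gives a 1.3-fold lower number from compound 2 to compound 3 (0.12 log units; within the scatter) and so leaves methoxy and ethoxy indistinguishable at this position. Ethoxy in place of hydrogen on the aromatic carbon gives a 2.2-fold lower number from compound 1 to compound 3 (0.34 log units; beyond the scatter) and is the first step in this small set to pass beyond the scatter, although only modestly, whereas methoxy in the same place gives a 1.7-fold lower number from compound 1 to compound 2 (0.22 log units; within the scatter) and does not pass it. Nothing available explains this small difference between the two steps.

The compounds shown leave open whether a longer chain such as butoxy would continue this slight trend or stay within the scatter. They also leave open how an amine or a carboxylic acid at this aromatic carbon would read in this assay.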